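Swapping Phenyl for Anilino on the Amide Carbonyl

The compounds below may be only part of what the source reports. "The series", "measured", "known", "first", "only" and "open" are said of these compounds alone.

Compound 1 `Cc1nc(NC(=O)c2ccccc2)c2nn(-c3ccccc3)cc2n1` is the starting point. In an assay on CHO cells for displacement of a labelled ligand from adenosine receptor A1 (Homo sapiens), read by scintillation counting, with a stated time of 120 min, tested at 1 uM (a higher number here means more inhibition at the concentration tested (going by the name of the read-out), a lower number less inhibition), compound 1 gives 30%, the second highest of three numbers. Its nearest neighbour is compound 2 `COc1ccc(-n2cc3nc(Cc4ccccc4)nc(N)c3n2)cc1`, which in this assay gives 40%, a number within the scatter of compound 1. Furthest away is compound 3 `O=C(Nc1nc(-c2ccccc2)nc2cn(-c3ccccc3)nc12)c1ccccc1`, which in this assay gives 5%; the step of a number 25 percentage points lower from compound 1 to compound 3 (beyond the scatter), phenyl in place of methyl on an aromatic carbon, is a modest loss beyond the scatter.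

Compound 4 `Cc1nc(NC(=O)Nc2ccccc2)c2nn(-c3ccccc3)cc2n1` differs from compound 1 in one place: anilino in place of phenyl on a carbonyl carbon. Among the measured compounds shown here, no measured step changes anything at this carbonyl carbon; the single measured step, from compound 1 to compound 3, touches a different part of the shared core and so bears little on the question. For the measured compounds named here, with no guiding step, the expectation for compound 4 is a change no larger than the usual scatter, in either direction. The estimated value of compound 4 in this assay is 30%, with a range from 10% to 50%, which means an expected step of no change at the digits printed from compound 1 to compound 4 (within the scatter).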

Compound 4, a percentage reported as inhibition, at one concentration (the size of the read-out at that concentration, not a potency): 1%
Beside the measured number, compound 4's estimate is 29 percentage points above it; measured number outside the range, below it.
By their numbers in this assay, from the lowest: compounds 4 and 3 (each within the scatter of the next); then compounds 1 and 2 (each within the scatter of the next).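

At the carbonyl carbon, this assay shows a number 29 percentage points lower from compound 1 to compound 4 (beyond the scatter), so this position, which the earlier step left untouched, is not indifferent to the swap. The two groups have the same six-membered carbon ring, yet anilino adds a nitrogen and a hydrogen-bond donor that phenyl lacks, so a small change in what links the ring to the carbonyl carbon is enough to move the number beyond the scatter. Nothing available here accounts for the loss or shows which feature of the anilino group matters.

Still open, from the compounds shown here alone, is whether the number at this carbonyl carbon depends on having an aromatic ring there at all, a question that a cyclohexyl group could address. A pyridyl ring in place of phenyl would show whether this position also responds to a nitrogen placed within the ring.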